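The source may report more compounds than this note shows. Statements on the series, on what has been measured and on what is new or still open speak of the compounds shown alone.

Three compounds share one core and differ only in the group on a saturated chain carbon bound to an aromatic carbon and a saturated chain carbon. Compound 1 `CC(C)C(c1ccc(-c2ccc3cccc(F)c3c2)[nH]c1=O)N1CCCCS1(=O)=O` gives 122 nM in a functional assay on CHO cells for antagonist activity at prostaglandin E2 receptor EP3 subtype (Homo sapiens), read by cAMP accumulation; a lower number here means a stronger inhibitor, a higher number a weaker inhibitor. Compound 2 `CC(C)C(Nc1nnc[nH]1)c1ccc(-c2ccc3cccc(F)c3c2)[nH]c1=O` gives 185 nM, and compound 3 `CC(C)C(Cc1nnc[nH]1)c1ccc(-c2ccc3cccc(F)c3c2)[nH]c1=O` gives 17 nM. Compound 3 stands lowest of the three: the step of a 7.2-fold lower number from compound 1 to compound 3 (0.86 log units; beyond the scatter) and the step of an 11-fold lower number from compound 2 to compound 3 (1.04 log units; beyond the scatter) both lie beyond the scatter, so the triazolylmethyl group sets compound 3 clearly apart from the other two, whose values lie within the scatter of each other. The unmeasured compound 4 `CC(C)C(c1ccc(-c2ccc3cccc(F)c3c2)[nH]c1=O)N1CCN/C1=N\C#N` carries a group of 8 heavy atoms (4 carbon, 4 nitrogen; one five-membered non-aromatic ring with 2 hetero atoms) in place of a group of 6 heavy atoms (3 carbon, 3 nitrogen; one five-membered aromatic ring with 3 hetero atoms), on a saturated chain carbon bound to an aromatic carbon and a saturated chain carbon. This change removes the very group that set compound 3 apart, and compound 4, like compound 1, carries a non-aromatic ring rather than an aromatic one. Those two measured steps therefore bear on it in reverse, and a rise in this assay of roughly their size is expected, though the entering ring is new and nothing measured speaks to it directly. Compound 4 is expected to give about 110 nM, between 35 nM and 350 nM, which means a step of a 6.5-fold higher number from compound 3 to compound 4 (0.81 log units; beyond the scatter).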

Compound 4, half-maximal inhibitory concentration: 38 nM
The estimate for compound 4 lay 2.9-fold (0.46 log units) above the measured number; the range from low to high includes it.
By their numbers in this assay, from the lowest: compound 3; then compound 4; then compounds 1 and 2 (each within the scatter of the next).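

For the compounds shown here, with compound 4, a non-aromatic ring on this saturated chain carbon reaches a level that compound 1, the only earlier compound with a non-aromatic ring here, did not, giving a 3.2-fold lower number from compound 1 to compound 4 (0.51 log units; beyond the scatter) and also a 4.9-fold lower number from compound 2 to compound 4 (0.69 log units; beyond the scatter) as a second clear gain. An aromatic triazole ring is therefore not required for a number below those of compound 1 and compound 2, and aromaticity alone does not sort these groups: compound 2 carries an aromatic ring and still stands above compound 4, while the (4H-1,2,4-triazol-3-yl)methyl group keeps the lowest place, with a 2.2-fold higher number from compound 3 to compound 4 (0.35 log units; beyond the scatter) as the price of leaving it. No measurement at hand explains why the entering ring performs as it does.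

Which part of the entering group matters remains open, for instance whether the same five-membered ring would hold its value with a carbonyl in place of the double bond that carries the nitrile. Also open, as far as these compounds go, is how a carboxylic acid or a simple amine would compare on this saturated chain carbon.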